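Methyl in Place of Bromo on a Cytotoxicity Read-out

The source may hold more compounds than are shown below. What is called first, only, known or untested is meant among the compounds shown, and "the series" means these compounds.

Among the compounds with values here, compound 2 `Clc1ccc2c(NCCCCNc3nccc(Nc4ccc(Br)cc4)n3)ccnc2c1` is the only compound here with a number: in an ADME assay on Vero cells (Chlorocebus sabaeus) for cytotoxicity, read by neutral red uptake, with a stated time of 72 h (on this read-out lower numbers stand for stronger inhibition and higher numbers for weaker inhibition), compound 2 gives 10000 nM. Compound 1 `Fc1ccc(Nc2ccnc(NCCCCNc3ccnc4cc(Cl)ccc34)n2)cc1` in this assay gives "not active" (no number reported), with no number reported. Compound 3 `Cc1ccc(Nc2ccnc(NCCCCNc3ccnc4cc(Cl)ccc34)n2)cc1` differs from compound 2 by methyl in place of bromo on an aromatic carbon. No step between two measured compounds is shown, so the size of this change is not known from the data; a step within the scatter is expected, leaning if anything toward a higher number. Compound 3 is expected to give 15000 nM, within 6000 nM to 40000 nM. The expected step is a 1.5-fold higher number from compound 2 to compound 3 (0.18 log units; within the scatter).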

Compound 3, half-maximal inhibitory concentration: 19300 nM
Compound 3: middle estimate off by 1.3-fold (0.11 log units), on the low side, within the range that was stated.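

Methyl in place of bromo on this aromatic carbon gives in this assay a 1.9-fold higher number from compound 2 to compound 3 (0.29 log units; within the scatter), the only size of step shown at this position, and it stays within the scatter. So 4-bromophenyl and 4-methylphenyl read alike on this assay, while steps to compound 1 cannot be read, as it has no number. Nothing shown bears on the reason for this result.

Going by these compounds, whether a carboxylic acid or an amine on this carbon would carry the number beyond the scatter remains open. So does whether the same exchange would read alike on another core.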